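Swapping a biphenyl for a styrene in a bile acid receptor ligand

A few compounds are considered here, and "the series" means these few. Any claim that something is new, unique, unknown or untested is made for them only; others in the source may bear on it.

Three compounds share one core and differ only in the group on the far aromatic ring. Compound 1 `COC(=O)/C=C/c1cccc(N(Cc2ccc(/C=C/c3c(C)cc(C)cc3C)cc2)C(=O)C(C)C)c1` gives 149 nM in an assay on isolated protein with Bile acid receptor (Homo sapiens) as the target; on this read-out lower numbers stand for an effect already at smaller amounts and higher numbers for an effect only at larger amounts of compound; compound 2 `COC(=O)/C=C/c1cccc(N(Cc2ccc(/C=C/c3cccc(F)c3)cc2)C(=O)C(C)C)c1` gives 71 nM; compound 3 `COC(=O)/C=C/c1cccc(N(Cc2ccc(-c3cccc(C)c3)cc2)C(=O)C(C)C)c1` gives 163 nM, the highest number of the three, though its gap to compound 1 is within the scatter. Compound 4 `COC(=O)/C=C/c1cccc(N(Cc2ccc(/C=C/c3ccccc3)cc2)C(=O)C(C)C)c1` carries 2-phenylethenyl in place of 3-methylphenyl on an aromatic carbon. Among the measured compounds shown here, two measured steps bear on this: a 2.3-fold higher number from compound 2 to compound 3 (0.36 log units; beyond the scatter) and a 1.1-fold higher number from compound 1 to compound 3 (0.04 log units; within the scatter). Returning to an ethenyl-linked phenyl therefore seems likely to bring the number down modestly, landing between compound 2 and compound 1. Compound 4 is expected to reach about 100 nM in this assay, within 45 nM to 220 nM, a step of a 1.6-fold lower number from compound 3 to compound 4 (0.21 log units; within the scatter).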

Compound 4, half-maximal effective concentration: 65 nM
The estimate for compound 4 lay 1.5-fold (0.19 log units) above the measured number, and the stated range covers the measured number.
By their numbers in this assay, from the lowest: compounds 4 and 2 (each within the scatter of the next); then compounds 1 and 3 (each within the scatter of the next).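

In this assay the 2-phenylethenyl group on this aromatic carbon gives a 2.5-fold lower number from compound 3 to compound 4 (0.40 log units; beyond the scatter) in place of 3-methylphenyl. The plain phenyl on the double bond gives a 2.3-fold lower number from compound 1 to compound 4 (0.36 log units; beyond the scatter) in place of 2,4,6-trimethylphenyl, while the fluoro makes little difference, with a 1.1-fold lower number from compound 2 to compound 4 (0.04 log units; within the scatter) when hydrogen replaces it. Nothing measured here explains these steps. As far as these compounds go, whether an amine or a carboxylic acid on that phenyl ring, or a longer chain in place of the ethenyl link, would keep the number this low remains open.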